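Halogen swaps on the benzyl ring of a hydroxypiperidine series

This account rests on a few compounds, and the source may have more. Where it says the series, first, only, none or still open, it means among the compounds named here.

Compound 1 `O=c1c2cnn(-c3ccc(F)cc3)c2ncn1CC1(O)CCN(Cc2ccc(Cl)cc2)CC1`, compound 2 `O=c1c2cnn(-c3ccc(F)cc3)c2ncn1CC1(O)CCN(Cc2ccc(Br)cc2)CC1` and compound 3 `O=c1c2cnn(-c3ccc(F)cc3)c2ncn1CC1(O)CCN(Cc2ccc(Cl)cc2Cl)CC1` share one core and differ only in the substitution of the benzyl ring. In an assay on Sf21 cells for inhibition of ubiquitin carboxyl-terminal hydrolase 7 (Homo sapiens), read by spectrophotometry, with stated times of 30 min and 2 h (on this read-out lower numbers stand for stronger inhibition and higher numbers for weaker inhibition), compound 1 gives 8000 nM, compound 2 gives 6700 nM and compound 3 gives 3300 nM. The change bromo in place of chloro on an aromatic carbon produces a 1.2-fold lower number from compound 1 to compound 2 (0.08 log units; within the scatter), so compounds 1 and 2 cannot be ordered. Adding a chloro group produces a 2.4-fold lower number from compound 1 to compound 3 (0.38 log units; beyond the scatter), and the larger swap produces a 2.0-fold lower number from compound 2 to compound 3 (0.31 log units; beyond the scatter). Compound 3 therefore holds the lowest number of the three, with both steps to it beyond the scatter.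

Compound 4 `O=c1c2cnn(-c3ccc(F)cc3)c2ncn1CC1(O)CCN(Cc2ccc(Br)cc2Cl)CC1` has not yet been measured. It differs from compound 3 by bromo in place of chloro on an aromatic carbon. Within the data shown here, this is the same kind of change as the one from compound 1 to compound 2, with one difference in the surroundings: in compound 3 the place is meta to a chloro group as well as para to a large group, whereas in compound 1 it is para to a large group only. The difference between the two starting compounds is chloro in place of hydrogen on an aromatic carbon.

Because the earlier step of a 1.2-fold lower number from compound 1 to compound 2 (0.08 log units; within the scatter) stayed within the scatter, compound 4 is expected to move from compound 3 by about a 1.2-fold lower number from compound 3 to compound 4 (0.07 log units; within the scatter). The expected value for compound 4 in this assay is 2800 nM, most likely between 1400 nM and 5600 nM.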

Compound 4, half-maximal inhibitory concentration: 1900 nM
Estimate against measurement, compound 4: 1.5-fold (0.17 log units) above, within the range that was stated.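

In this assay, bromo in place of chloro stays within the scatter on the 2,4-dichlorobenzyl compound too, at a 1.7-fold lower number from compound 3 to compound 4 (0.24 log units; within the scatter), and its two readings do not differ beyond the scatter: the same change on two cores in this assay, a 1.2-fold lower number (0.08 log units; within the scatter) from compound 1 to compound 2 and a 1.7-fold lower number (0.24 log units; within the scatter) from compound 3 to compound 4, 1.5-fold (0.16 log units) apart, within the scatter of two such steps. Chloro in place of hydrogen also carries over, now on the bromo compound, at a 3.5-fold lower number from compound 2 to compound 4 (0.55 log units; beyond the scatter), and again the two readings agree within the scatter: the same change on two cores in this assay, a 2.4-fold lower number (0.38 log units; beyond the scatter) from compound 1 to compound 3 and a 3.5-fold lower number (0.55 log units; beyond the scatter) from compound 2 to compound 4, 1.5-fold (0.16 log units) apart, within the scatter of two such steps. With both changes together the step is a 4.2-fold lower number from compound 1 to compound 4 (0.62 log units; beyond the scatter), so the two changes carry across these cores without a detectable difference, but this rests on four compounds in one assay and shows neither that they would carry to a different core nor why the steps have the size they do.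

The compounds shown leave open whether the same steps hold for other groups on the benzyl ring, such as fluoro, iodo, methoxy or an amine. They also leave open whether the steps survive when the fluoro group on the shared core gives way to a nitrile or a carboxylic acid.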